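A few compounds are considered here, and "the series" means these few. Any claim that something is new, unique, unknown or untested is made for them only; others in the source may bear on it.

Series notes. The shared core carries a ring amine whose substituent is varied. In an ADME assay on MT4 cells (Homo sapiens) for cytotoxicity, read by MTT assay, with a stated time of 5 days (a lower number here means that less compound is tolerated, a higher number that more compound is tolerated), compound 1 `COc1cc(Cc2cnc(/N=C3\C(=O)N(CN4CCN(Cc5ccccc5)CC4)c4ccc(Cl)cc43)nc2N)cc(OC)c1OC` gives 36.1 ug/mL, compound 2 `COc1cc(Cc2cnc(/N=C3\C(=O)N(CN4CCN(c5ccc(F)cc5)CC4)c4ccc(Cl)cc43)nc2N)cc(OC)c1OC` gives 65.6 ug/mL, and compound 3 `COc1cccc(N2CCN(CN3C(=O)/C(=N\c4ncc(Cc5cc(OC)c(OC)c(OC)c5)c(N)n4)c4cc(Cl)ccc43)CC2)c1` gives 32.6 ug/mL. Compound 3 sits at the low end of the three numbers in this assay, yet within the scatter of each neighbour: a 1.1-fold lower number from compound 1 to compound 3 (0.04 log units; within the scatter) and a 2.0-fold lower number from compound 2 to compound 3 (0.30 log units; within the scatter). The remaining pair, a 1.8-fold higher number from compound 1 to compound 2 (0.26 log units; within the scatter), is also within the scatter, so the three substituents on the ring nitrogen have not separated from one another here.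

Compound 4 `COc1cc(Cc2cnc(/N=C3\C(=O)N(CN4CCN(c5ccc(Cl)cc5)CC4)c4ccc(Cl)cc43)nc2N)cc(OC)c1OC` is not yet measured. It differs from compound 3 by 4-chlorophenyl in place of 3-methoxyphenyl on an amine nitrogen in a ring. The changes that bear on this are the swaps at the same ring nitrogen already measured, from benzyl or 4-fluorophenyl to 3-methoxyphenyl and between the two aryl groups, none of which left the scatter. Among the compounds with values here, a 4-chlorophenyl there is another aryl group of similar size, and nothing measured so far suggests the substituent at this position moves the number in this assay.

Compound 4 is therefore expected to give about 38 ug/mL in this assay, with a range of 19 ug/mL to 76 ug/mL. The expected step is a 1.2-fold higher number from compound 3 to compound 4 (0.07 log units; within the scatter), meaning no change beyond the scatter.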

Compound 4, half-maximal cytotoxic concentration: 38.6 ug/mL
Beside the measured number, compound 4's estimate is 1.0-fold (0.01 log units) below it; the measured number falls inside the stated range.
By their numbers in this assay, from the lowest: compounds 3, 1, 4 and 2 (each within the scatter of the next).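

Working on the ring amine, this assay shows that the step to a para-free comparison is not needed: the direct swap of 4-chlorophenyl for 3-methoxyphenyl on the amine nitrogen in a ring (a 1.2-fold higher number from compound 3 to compound 4 (0.07 log units; within the scatter)) stays inside the scatter, and so does the first change made on the aryl ring itself, chloro in place of fluoro on an aromatic carbon (a 1.7-fold lower number from compound 2 to compound 4 (0.23 log units; within the scatter)). Set against the benzyl group, 4-chlorophenyl also gives no separation (a 1.1-fold higher number from compound 1 to compound 4 (0.03 log units; within the scatter)), so benzyl and all three aryl groups at this ring nitrogen now stand unseparated, with no exception among the four compounds. Nothing available explains this flat picture.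

From the compounds shown here alone, all four compounds carry a benzyl or aryl group at this nitrogen, so it remains open whether a short alkyl chain, an acyl group or a carboxylic acid there would move the number beyond the scatter. The rest of the shared core is the same throughout, which leaves open how the number responds to a change elsewhere, for instance at the chloro on the core.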